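The source may report more compounds than this note shows. Statements on the series, on what has been measured and on what is new or still open speak of the compounds shown alone.

Compound 1 `CC1(C)CCC[C@]2(C)[C@@H](/C=C/C3=CCOC3=O)C(C=O)=CC(=O)[C@@H]12`: 48500 nM
Compound 2 `CC1=CC(=O)[C@H]2C(C)(C)CCC[C@]2(C)[C@H]1/C=C/c1ccoc1`: 17200 nM

Both numbers come from a functional assay on SK-N-SH cells (Homo sapiens) for inhibition, read by sulforhodamine B assay; on this read-out higher numbers stand for lower toxicity in this test and lower numbers for higher toxicity in this test. For the measured compounds named here, with only two compounds measured, compound 2 holds the lower number at 17200 nM, and its gap to compound 1 at 48500 nM lies beyond the usual scatter. On this read-out, that makes compound 2 the more toxic of the pair.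

The next compound to be tested is compound 3 `CC1=CC(=O)[C@H]2C(C)(C)CCC[C@]2(C)[C@H]1/C=C/C1=CCOC1=O`, which differs from compound 2 in a single place: a group of 6 heavy atoms (4 carbon, 2 oxygen; one five-membered non-aromatic ring with 1 hetero atom) in place of a group of 5 heavy atoms (4 carbon, 1 oxygen; one five-membered aromatic ring with 1 hetero atom), on a double-bonded chain carbon bound to a double-bonded chain carbon. Going by the values given here, no measured pair isolates this swap, so any forecast is uncertain. The one available hint is that compound 1, which carries the same incoming ring but also differs elsewhere, gives 48500 nM. This points to a modest rise rather than a fall. The expected change is a 1.5-fold higher number from compound 2 to compound 3 (0.18 log units; within the scatter), a small move towards a higher number that may well stay within the scatter. For compound 3 the estimated value is 26000 nM, with an expected range of 9000 nM to 70000 nM.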

Compound 3, concentration lethal to 50% of the cells: 20800 nM
Compound 3: the middle estimate sits 1.3-fold (0.10 log units) above what was measured, within the range that was stated.
By their numbers in this assay, from the lowest: compounds 2 and 3 (each within the scatter of the next); then compound 1.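

In this assay the swap of furan-3-yl for the five-membered non-aromatic ring, on a double-bonded chain carbon bound to a double-bonded chain carbon, gives a 1.2-fold higher number from compound 2 to compound 3 (0.08 log units; within the scatter) and so leaves the two rings indistinguishable in this test at this position. For the compounds shown here, the change elsewhere in the molecule does register: methyl in place of formyl on a double-bonded ring carbon, with the non-aromatic ring kept the same, gives a 2.3-fold lower number from compound 1 to compound 3 (0.37 log units; beyond the scatter) and is the first single-place change here to lie beyond the scatter, so with this ring the formyl compound is the less toxic of that pair. Nothing measured here explains why either step has the size it has.

Going by these compounds alone, only two rings are seen on the chain and only two groups on the ring carbon, so it remains open how an amine or a carboxylic acid on the chain, or a hydroxymethyl group on the ring carbon, would read in this test. Also open, on these data alone, is whether formyl in place of methyl would have a similar effect with furan-3-yl on the chain.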